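Phenyl removed from a dicyanopyridine core: permeability outlook

The source may report more compounds than this note shows. Statements on the series, on what has been measured and on what is new or still open speak of the compounds shown alone.

Compound 1 `N#Cc1c(Cl)nc(NCCC2CCN(Cc3ccccc3)CC2)c(C#N)c1-c1ccccc1` has no single number in an ADME assay for permeability, using PAMPA, with a stated time of 4 h, tested at 1 mg/mL; on this read-out lower numbers stand for lower permeability and higher numbers for higher permeability; the entry for compound 1 in this assay reads "not determined" (no result reported), since no result was reported for it. Going by the values given here, its relative compound 2 `N#Cc1c(Cl)nc(NCCCC2CCN(Cc3ccccc3)CC2)c(C#N)c1-c1ccccc1`, which carries a longer chain to the piperidine, gives 10.1 10^-6 cm/s in this assay, and that figure is the only measured value in the set. Compound 3 `N#Cc1cc(C#N)c(NCCC2CCN(Cc3ccccc3)CC2)nc1Cl` is not yet measured. It differs from compound 1 by hydrogen in place of phenyl on an aromatic carbon. Among the compounds with values here, no step between measured compounds exists here, so the size of the change from compound 1 to compound 3 in this assay can only be anticipated: a modest shift is expected, most likely downward but possibly no larger than the scatter. For compound 3 the estimated apparent permeability is 6 10^-6 cm/s, with a range from 2 10^-6 cm/s to 15 10^-6 cm/s.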

Compound 3, apparent permeability: 8.52 10^-6 cm/s
The estimate for compound 3 lay 1.4-fold (0.15 log units) below the measured number; the measured number falls inside the stated range.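

Going by these compounds alone, compound 1 has no single number in this assay, and no step to compound 3 can be read. The compounds shown leave open how hydrogen in place of phenyl shifts apparent permeability. No supporting evidence bears on this result.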